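From methoxy to bromo on the shared core

The source may hold more compounds than are shown below. What is called first, only, known or untested is meant among the compounds shown, and "the series" means these compounds.

Compound 2 `COc1ccc(-n2ccc(=O)c(C(=O)Nc3ccc(Oc4ccnc5[nH]ccc45)c(F)c3)n2)cc1` gives 46400 nM in a functional assay on PC-3 cells (Homo sapiens) for cytotoxicity, read by MTT assay, with a stated time of 72 h; on this read-out lower numbers stand for stronger inhibition and higher numbers for weaker inhibition. For the measured compounds named here, only one other compound has been measured: compound 1 `O=C(Nc1ccc(Oc2ccnc3[nH]ccc23)c(F)c1)c1nn(-c2ccc(Cl)cc2)ccc1=O`, which in this assay gives 42500 nM, and the two numbers lie within the scatter of each other. Compound 1 differs from compound 2 only in carrying chloro where compound 2 carries methoxy, and that step, a 1.1-fold higher number from compound 1 to compound 2 (0.04 log units; within the scatter), stayed within the scatter. Compound 3 `O=C(Nc1ccc(Oc2ccnc3[nH]ccc23)c(F)c1)c1nn(-c2ccc(Br)cc2)ccc1=O` carries the change (bromo in place of methoxy on an aromatic carbon). Going by the values given here, the only step that bears on this exchange is the chloro-to-methoxy one, which moved the number hardly at all, so putting bromo on that aromatic carbon is expected to leave the number roughly where compound 1 and compound 2 sit, with no shift beyond the scatter. Compound 3 is therefore expected to give 40000 nM, with a range from 15000 nM to 100000 nM. That amounts to an estimated step of a 1.2-fold lower number from compound 2 to compound 3 (0.06 log units; within the scatter).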

Compound 3, half-maximal inhibitory concentration: 40800 nM
Compound 3: middle estimate off by 1.0-fold (0.01 log units), on the low side; the range from low to high includes it.
By their numbers in this assay, from the lowest: compounds 3, 1 and 2 (each within the scatter of the next).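

In this assay, going from 4-methoxyphenyl to 4-bromophenyl gives a 1.1-fold lower number from compound 2 to compound 3 (0.06 log units; within the scatter) and exchanging chloro for bromo gives a 1.0-fold lower number from compound 1 to compound 3 (0.02 log units; within the scatter) and both steps stay within the scatter. This aromatic carbon has now carried three different groups, including methoxy with its two heavy atoms and one hydrogen-bond acceptor and bromo with one heavy atom and no acceptor, and the assay does not separate the three compounds. No measurement is available to explain why these exchanges leave the number in the same range.

As far as these compounds go, it remains open whether an amine, a carboxylic acid or a longer chain such as butoxy on this carbon would move the number beyond the scatter. From the compounds shown here alone, it also remains open whether a change elsewhere on the shared core would do so.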